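The compounds below may be only part of what the source reports. "The series", "measured", "known", "first", "only" and "open" are said of these compounds alone.

Measured compounds:
compound 1 `O=C(Nc1cccc(-n2cc(-c3ccncc3)c(-c3ccc(Cl)c(O)c3)n2)c1)Nc1cccc(C(F)(F)F)c1`, 1400 nM
compound 2 `COc1cc(-c2nn(-c3cccc(NC(=O)Nc4cc(C(F)(F)F)cc(C(F)(F)F)c4)c3)cc2-c2ccncc2)ccc1Cl`, 498 nM
compound 3 `COc1cc(-c2nn(-c3cccc(NC(=O)c4cccc(C(F)(F)F)c4)c3)cc2-c2ccncc2)ccc1Cl`, 1450 nM

In a functional assay on CCRF-CEM cells (Homo sapiens) for inhibition, read by sulforhodamine B assay, with a stated time of 48 h (a higher number here means a weaker inhibitor of growth, a lower number a stronger inhibitor of growth), compound 3 gives 1450 nM, the highest of the three numbers. Compound 1 stands nearest to it, and its value of 1400 nM lies within the scatter of compound 3, so these two cannot be placed in any order. Compound 2, at 498 nM, stands furthest from compound 3 and is the only one separated from it beyond the scatter, with the lower number.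

Compound 4 `COc1cc(-c2nn(-c3cccc(NC(=O)Nc4ccc(Cl)c(Cl)c4)c3)cc2-c2ccncc2)ccc1Cl` has not been measured. It arises from compound 3 by one change: (3,4-dichlorophenyl)amino in place of 3-(trifluoromethyl)phenyl on a carbonyl carbon. Within the data shown here, compound 2 also carries a carbamoyl linkage of this kind, and in this assay compound 2 gives 498 nM, the lowest number of the three, though its aryl group differs from that of compound 4, so no single measured step isolates this change. On that basis the expected step, a 2.1-fold lower number from compound 3 to compound 4 (0.32 log units; beyond the scatter), is a decrease near the edge of the scatter. The estimate for compound 4 in this assay is 700 nM, with a range from 250 nM to 2000 nM.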

Compound 4, concentration for 50% growth inhibition: 1040 nM
Beside the measured number, compound 4's estimate is 1.5-fold (0.17 log units) below it, and the stated range covers the measured number.
By their numbers in this assay, from the lowest: compound 2; then compounds 4, 1 and 3 (each within the scatter of the next).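

In this assay, among these compounds, placing (3,4-dichlorophenyl)amino in place of 3-(trifluoromethyl)phenyl on a carbonyl carbon gives a 1.4-fold lower number from compound 3 to compound 4 (0.14 log units; within the scatter), the first comparison at this position between compounds that differ in one place. This change turns a (3-(trifluoromethyl)phenyl)carbonyl into a (3,4-dichlorophenyl)carbamoyl and adds a hydrogen-bond donor, yet compound 3 and compound 4 cannot be placed in any order, so this replacement shows no measurable gain or loss in growth inhibition. No measured property of these compounds bears on this result, and the data offer no account of it.

Among the compounds shown here, the single change replaces the linkage and the ring substituents together, so what each contributes on its own remains open, and the (3,4-dichlorophenyl)carbonyl and the (3-(trifluoromethyl)phenyl)carbamoyl counterparts on the same core would be needed to separate them. From the compounds shown here alone, it also remains open how far this position tolerates groups without an aromatic ring, such as a piperidine or a cyclohexylamino group on the same carbonyl carbon.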